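Shortening the Ether Chain on a Shared Core

A few compounds are considered here, and "the series" means these few. Any claim that something is new, unique, unknown or untested is made for them only; others in the source may bear on it.

Compound 1 `[O-][n+]1nc(NCOC2CCCCC2)[n+]([O-])c2ccccc21`: 4390 nM
Compound 2 `COc1ccc2c(c1)[n+]([O-])nc(NCOCc1ccccc1)[n+]2[O-]`: 2400 nM
Compound 3 `[O-][n+]1nc(NCOCc2ccc(C(F)(F)F)cc2)[n+]([O-])c2ccccc21`: 390 nM

Of the compounds shown here, three sharing one core have been tested in a functional assay on KB cells (Homo sapiens) for cytotoxicity, read by MTT assay, with a stated time of 72 h; on this read-out higher numbers stand for weaker inhibition and lower numbers for stronger inhibition. Compound 1 shows the highest number of the three. Its nearest neighbour is compound 2, whose value lies within the usual scatter of compound 1, so the two cannot be told apart on these data. Compound 3 stands well apart from compound 1, its number being beyond the scatter and clearly lower.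

Compound 4 `CCOCNc1n[n+]([O-])c2ccccc2[n+]1[O-]` is the next compound in the series and has not yet been measured in this assay. Compared with compound 1, the change is ethyl in place of cyclohexyl on an oxygen on a saturated carbon. Among the measured compounds shown here, no pair among the measured compounds differs in only one place, so there is no measured step that directly shows what this change does. Compound 2 and compound 3 differ from compound 1 in more than one place at once, and what they show cannot be separated into single contributions.

On these grounds, the step from compound 1 to compound 4 is expected to be small in this assay, with no confident direction, and most likely not beyond the scatter: a 1.4-fold higher number from compound 1 to compound 4 (0.14 log units; within the scatter). Compound 4 is therefore estimated at 6000 nM, within a range from 2000 nM to 18000 nM.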

Compound 4, half-maximal inhibitory concentration: 2800 nM
For compound 4 the middle estimate is 2.1-fold (0.33 log units) above the measured one, and the stated range covers the measured number.
By their numbers in this assay, from the lowest: compound 3; then compounds 2, 4 and 1 (each within the scatter of the next).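

In this assay, the exchange of cyclohexyl for ethyl gives the series its first step that changes one place only, and the step of a 1.6-fold lower number from compound 1 to compound 4 (0.20 log units; within the scatter) lies within the usual scatter of repeated measurements. At this position, on an oxygen on a saturated carbon, the six-membered non-aromatic ring of carbon only can therefore give way to a short open chain without a difference that this read-out can resolve, so cyclohexyloxy and ethoxy cannot be told apart here. No measurement at hand bears on why these two groups read alike.

What the compounds shown leave open is how far this tolerance extends, since a single step within the scatter says nothing about other groups on the same oxygen, such as methyl, a longer chain like hexyl, or a chain ending in an amine. From the compounds shown here alone, it also remains open whether the exchange of cyclohexyl for ethyl would read the same way on a core carrying a methoxy group, or with a benzyl group as the starting point.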